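Amide nitrogen change from compound 2 to compound 4

The source may hold more compounds than are shown below. What is called first, only, known or untested is meant among the compounds shown, and "the series" means these compounds.

Compound 1, `O=C(/C=C/c1coc2cc(O)ccc2c1=O)NCc1ccc(F)cc1`: a limit of the assay, > 100000 nM
Compound 2, `COc1ccc2c(=O)c(/C=C/C(=O)Nc3ccccc3)coc2c1`: a limit of the assay, > 100000 nM
Compound 3, `O=C(/C=C/c1coc2cc(O)ccc2c1=O)NCc1ccccc1`: a limit of the assay, > 100000 nM

All three values come from a functional assay on HeLa cells (Homo sapiens) for inhibition, read by MTT assay, with a stated time of 48 h; on this read-out lower numbers stand for stronger inhibition and higher numbers for weaker inhibition. Every value shown is a limit rather than a number, (the limit of > 100000 nM in this assay, at which 3 of the 3 values shown sit), so compound 2 stands at that limit with no readable position among the others. Within the data shown here, the only one-place step among the measured compounds, a step that the two limits leave unreadable from compound 1 to compound 3, is likewise unreadable. Compound 4, `COc1ccc2c(=O)c(/C=C/C(=O)NCc3ccccc3F)coc2c1`, differs from compound 2 by 2-fluorobenzyl in place of phenyl on an amide-type nitrogen. Among the measured compounds shown here, no measured step bears readably on this change, so no step beyond the scatter is expected in this assay, and the estimated step of a number no higher from compound 2 to compound 4 (the limit leaves the size open) is near zero. Compound 4 is therefore expected to sit around 100000 nM, within 30000 nM to 300000 nM, most likely again reported only as a limit.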

Compound 4, half-maximal inhibitory concentration: > 100000 nM
Compound 4: no number, only a limit (the forecaster's own chance of this, stated with the estimate: 75%); the middle value sits exactly at the limit.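

No step can be read from compound 2 to compound 4, since both values are limits of the assay: the limit of > 100000 nM in this assay, at which 4 of the 4 values shown sit.
The compounds shown leave open how 2-fluorobenzyl and phenyl on an amide-type nitrogen compare, and how the four compounds rank.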